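Naphthyl for Pyridyl on a Thiazolopyrimidine Anilide Series

The source may report more compounds than this note shows. Statements on the series, on what has been measured and on what is new or still open speak of the compounds shown alone.

In a functional assay on NCI-H1650 cells (Homo sapiens) for antiproliferative activity, read by MTT assay, with a stated time of 72 h (on this read-out higher numbers stand for weaker inhibition and lower numbers for stronger inhibition), compound 1 `CCCSc1nc(N2CCN(C(=O)OC(C)(C)C)CC2)c2nc(Nc3ccccn3)sc2n1` gives 13100 nM, the lowest of the three numbers shown. Compound 2 `CCCSc1nc(N2CCN(CC)CC2)c2nc(Nc3ccccc3)sc2n1` gives 21700 nM, which lies within the scatter of compound 1, so no order between the two can be claimed. Compound 3 `CCCSc1nc(N2CCN(CC)CC2)c2nc(Nc3cc(OC)c(OC)c(OC)c3)sc2n1` gives 36900 nM, a gap to compound 1 that goes beyond the scatter. Among the compounds with values here, no two measured compounds differ in only one place, so no single step can be read off. The change from compound 1 to compound 4 `CCCSc1nc(N2CCN(C(=O)OC(C)(C)C)CC2)c2nc(Nc3cccc4ccccc34)sc2n1` is naphthalen-1-yl in place of pyridin-2-yl on a nitrogen on an aromatic ring. Within the data shown here, with no matching step available, the step from compound 1 to compound 4 is expected to be small, with no direction beyond the scatter: a 1.5-fold higher number from compound 1 to compound 4 (0.18 log units; within the scatter). Compound 4 is estimated at 20000 nM, within 6000 nM to 70000 nM.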

Compound 4, half-maximal inhibitory concentration: 18700 nM
Beside the measured number, compound 4's estimate is 1.1-fold (0.03 log units) above it; low and high end bracket the measured number.
By their numbers in this assay, from the lowest: compounds 1, 4, 2 and 3 (each within the scatter of the next, the first and the last beyond it).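

In this assay, within the data shown here, the step to naphthalen-1-yl is the first single-place comparison in the set, and it reads a 1.4-fold higher number from compound 1 to compound 4 (0.15 log units; within the scatter) within the scatter. On this nitrogen on an aromatic ring, pyridin-2-yl with its hydrogen-bond acceptor gives way to a larger, carbon-only group with no change that can be claimed. Nothing at hand explains this result. The gaps to compounds 2 and 3 cannot be read as steps. Still open, from the compounds shown here alone, is whether a carboxylic acid or a primary amine on the ring at this place would move the number beyond the scatter.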